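From chloro to bromo on the benzyl ring

This account rests on a few compounds, and the source may have more. Where it says the series, first, only, none or still open, it means among the compounds named here.

Compound 3 `Clc1ccc(Cn2cc(CCCOc3cccc4cccnc34)nn2)cc1` gives 4.2 ug/mL in an ADME assay on HaCaT cells (Homo sapiens) for inhibition, read by sulforhodamine B assay, with a stated time of 48 h (a higher number here means a weaker inhibitor of growth, a lower number a stronger inhibitor of growth), the lowest of the two numbers shown. Its nearest neighbour is compound 2 `Fc1ccc(Cn2cc(CCCOc3cccc4cccnc34)nn2)cc1`, which in this assay gives 115 ug/mL. Compound 1 `Ic1ccc(Cn2cc(CCCOc3cccc4cccnc34)nn2)cc1` gives only a limit in this assay, namely > 250 ug/mL, which is the limit of > 250 ug/mL in this assay, at which 1 of the 3 values shown sits. The steps of a 27-fold lower number from compound 2 to compound 3 (1.44 log units; beyond the scatter) and an at least 59-fold lower number from compound 1 to compound 3 (1.77 log units; beyond the scatter) both set compound 3 well apart, while the step of an at least 2.1-fold lower number from compound 1 to compound 2 (0.33 log units; beyond the scatter) is smaller. Compound 4 `Brc1ccc(Cn2cc(CCCOc3cccc4cccnc34)nn2)cc1` differs from compound 3 by bromo in place of chloro on an aromatic carbon. The measured steps all exchange one halogen for another at the same place, and the numbers do not run in one direction from fluoro through chloro to iodo: chloro gave by far the lowest number, fluoro a much higher one, and iodo only a limit. Bromo has no measured neighbour that settles where it falls. The step of a 4.8-fold higher number from compound 3 to compound 4 (0.68 log units; beyond the scatter) is therefore expected to run upward in this assay, with its size uncertain. Compound 4 is expected to give about 20 ug/mL, between 4 ug/mL and 150 ug/mL.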

Compound 4, concentration for 50% growth inhibition: 29.2 ug/mL
Estimate against measurement, compound 4: 1.5-fold (0.16 log units) below; the measured number falls inside the stated range.
By their numbers in this assay, from the lowest: compound 3; then compound 4; then compound 2. At a limit, above all of these: compound 1.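

With bromo in place, chloro still stands alone at the low end in this assay, with a 7.0-fold higher number from compound 3 to compound 4 (0.84 log units; beyond the scatter), so compound 3 now lies beyond the scatter of every measured number in the set. Bromo also separates from the other two halogens, with a 3.9-fold lower number from compound 2 to compound 4 (0.60 log units; beyond the scatter) and an at least 8.5-fold lower number from compound 1 to compound 4 (0.93 log units; beyond the scatter), so the order does not run in one direction from fluoro to iodo, and bromo falls on the low side of fluoro while iodo stays highest. Compound 1 remains a limit, not a number: the limit of > 250 ug/mL in this assay, at which 1 of the 4 values shown sits.

The compounds shown do not tell why chloro stands apart from the other halogens at this place. They also leave open whether an amine, a carboxylic acid or a methoxy group on the benzyl ring, or a longer chain on the shared core, would come near compound 3.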